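Swapping Phenyl for tert-Butyl in a Receptor Agonist Series

The source may report more compounds than this note shows. Statements on the series, on what has been measured and on what is new or still open speak of the compounds shown alone.

Measured compounds:
Compound 1, `C(=N/OCc1ccccc1)\c1c(-c2ccc3ccccc3c2)nc2occn12`: 840 nM
Compound 2, `Clc1ccc(CO/N=C/c2c(-c3ccc(-c4ccccc4)cc3)nc3sccn23)cc1Cl`: "not active" (no number reported)
Compound 3, `Clc1ccc(CO/N=C/c2c(-c3ccc4ccccc4c3)nc3occn23)c(Cl)c1`: 1500 nM

All values come from an assay on HepG2 cells for agonist activity at nuclear receptor subfamily 1 group I member 3 (Homo sapiens), read by a luciferase reporter, with a stated time of 23 h; a higher number here means that more compound is needed for the effect, a lower number that less compound is needed. Compound 2 stands apart from the other two: in this assay compound 2 is recorded only as "not active" (no number reported), so no single number places it against compound 1 or compound 3.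

Compound 4, `CC(C)(C)c1ccc(-c2nc3sccn3c2/C=N/OCc2ccc(Cl)c(Cl)c2)cc1`, differs from compound 2 in one place: tert-butyl in place of phenyl on an aromatic carbon.

Within the data shown here, the only measured step between two compounds that differ in one place is a 1.8-fold higher number from compound 1 to compound 3 (0.25 log units; within the scatter). That step changes the group on the saturated chain carbon bound to an oxygen, not the aromatic carbon altered here, and compounds 1 and 3 share a core that differs from that of compounds 2 and 4. It therefore gives no guidance on tert-butyl in place of phenyl. Because compound 2 is recorded as "not active" (no number reported), the starting point itself carries no number, and the chance that compound 4 also returns no number is substantial. If a number does appear, compound 4 is expected to need a high concentration, estimated at 5000 nM, with a range from 800 nM to 30000 nM.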

Compound 4, half-maximal effective concentration: 2400 nM
Compound 4: middle estimate off by 2.1-fold (0.32 log units), on the high side; low and high end bracket the measured number.
By their numbers in this assay, from the lowest: compounds 1, 3 and 4 (each within the scatter of the next, the first and the last beyond it).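

In this assay, among these compounds, compound 4 gives 2400 nM while compound 2 carries no number, and no step between the two can be read. The compounds shown leave open how far tert-butyl in place of phenyl shifts the number. Nothing available here explains the result.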